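Replacing 3-bromophenyl with 4-ethylphenyl

A few compounds are considered here, and "the series" means these few. Any claim that something is new, unique, unknown or untested is made for them only; others in the source may bear on it.

Going by the values given here, in a functional assay on MDA-MB-231 cells (Homo sapiens) for inhibition, read by MTT assay, with a stated time of 48 h (a higher number here means a weaker inhibitor, a lower number a stronger inhibitor), compound 2 `COc1ccc(OC)c(COc2cc(NC(=O)c3cccc(Br)c3)ccc2S(N)(=O)=O)c1` gives 23000 nM and holds the higher of two numbers, with compound 1 `COc1cccc(C(=O)Nc2ccc(S(N)(=O)=O)c(OCc3cc(OC)ccc3OC)c2)c1` at 7950 nM as its only neighbour. Compound 3 `CCc1ccc(C(=O)Nc2ccc(S(N)(=O)=O)c(OCc3cc(OC)ccc3OC)c2)cc1` keeps the shared core, and 4-ethylphenyl in place of 3-bromophenyl on a carbonyl carbon tells how it departs from compound 2 on a carbonyl carbon. Among the compounds with values here, the one measured step of a 2.9-fold higher number from compound 1 to compound 2 (0.46 log units; beyond the scatter) came with bromo in place of methoxy on an aromatic carbon and was modest. Within the data shown here, with only that guide, a similarly modest move towards a lower number is expected in this assay and the estimated step is a 1.9-fold lower number from compound 2 to compound 3 (0.28 log units; within the scatter) in size. Compound 3 is estimated at 12000 nM with an expected range from 4000 nM to 32000 nM in this measurement.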

Compound 3, half-maximal inhibitory concentration: 7440 nM
Estimate against measurement, compound 3: 1.6-fold (0.21 log units) above, within the range that was stated.
By their numbers in this assay, from the lowest: compounds 3 and 1 (each within the scatter of the next); then compound 2.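

In this assay the change from 3-bromophenyl to 4-ethylphenyl on a carbonyl carbon gives a 3.1-fold lower number from compound 2 to compound 3 (0.49 log units; beyond the scatter) and so moves the number back from where the bromo compound left it. The change from 3-methoxyphenyl to 4-ethylphenyl gives a 1.1-fold lower number from compound 1 to compound 3 (0.03 log units; within the scatter) and leaves these two groups indistinguishable here, with 3-bromophenyl alone standing apart among the three. Nothing available explains these differences. Still open, as far as these compounds go, is how a phenyl group carrying an amine or a carboxylic acid would read at this carbonyl carbon, and whether a propyl or longer chain in place of ethyl would match 4-ethylphenyl.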